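A few compounds are considered here, and "the series" means these few. Any claim that something is new, unique, unknown or untested is made for them only; others in the source may bear on it.

Compound 3 `COc1cc([C@H]2C[C@]2(CO)C(=O)NCc2ccc(C)cc2)cc(OC)c1OC` sits at the low end of the two numbers obtained in a functional assay on HeLa cells (Homo sapiens) for cytotoxicity, read by MTT assay, with a stated time of 48 h; on this read-out lower numbers stand for stronger inhibition and higher numbers for weaker inhibition: compound 3 gives 57800 nM. Its nearest neighbour, compound 2 `COc1cc([C@@H]2C[C@@]2(CO)C(=O)Nc2ccccc2)cc(OC)c1OC`, gives 86400 nM in this assay, a gap that stays within the scatter, so the two cannot be ranked. Compound 1 `COc1cc([C@H]2C[C@@]2(CO)C(=O)NCc2ccc(C)cc2)cc(OC)c1OC` reaches only the limit of this assay, > 100000 nM, and so no number is known for it. Compound 4 `COc1cc([C@@H]2C[C@@]2(CO)C(=O)NCc2ccc(C)cc2)cc(OC)c1OC` has not yet been measured. It keeps every atom and bond of compound 3; (the two compounds have the same atoms and bonds and differ only in configuration as drawn: 2 of 2 stereo elements differ (all stereocentres are inverted: mirror images); a stereocentre at a saturated ring carbon is drawn R in compound 3 and S in compound 4; a stereocentre at a saturated ring carbon is drawn S in compound 3 and R in compound 4).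

One measured step speaks to a change of this kind: an at least 1.7-fold lower number from compound 1 to compound 3 (0.23 log units; that floor lies within the scatter). That step rests on the limit of > 100000 nM in this assay, at which 1 of the 3 values shown sits, and on the fact that (the fact that compounds 1 and 3 differ only in the configuration as drawn), and its size is not resolved beyond the scatter, so swapping a single stereocentre left no clear mark here. Going by the values given here, compound 4 inverts both centres at once, and no measured pair covers that. The expectation for this assay is therefore a step of no settled direction, and at most a modest one: compound 4 is estimated to give 80000 nM, between 30000 nM and 200000 nM, which means an expected step of a 1.4-fold higher number from compound 3 to compound 4 (0.14 log units; within the scatter), with a fair chance that only a limit is recorded.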

Compound 4, half-maximal inhibitory concentration: 41200 nM
The estimate for compound 4 lay 1.9-fold (0.29 log units) above the measured number, and the stated range covers the measured number.
By their numbers in this assay, from the lowest: compounds 4, 3 and 2 (each within the scatter of the next, the first and the last beyond it). At a limit, above all of these: compound 1.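

In this assay, inverting both stereocentres at once gives a 1.4-fold lower number from compound 3 to compound 4 (0.15 log units; within the scatter), so this mirror-image pair cannot be told apart, and the comparison is a clean one: the fact that compounds 3 and 4 differ only in the configuration as drawn. Against compound 1, whose value is only a limit, inverting a single stereocentre now gives an at least 2.4-fold lower number from compound 1 to compound 4 (0.38 log units; beyond the scatter), the first change of configuration here to clear the scatter, whereas an at least 1.7-fold lower number from compound 1 to compound 3 (0.23 log units; that floor lies within the scatter) did not, so the two single-centre changes away from compound 1 do not read alike. Going by these compounds alone, with the configuration as drawn unchanged, 4-methylbenzyl in place of phenyl on the amide-type nitrogen gives a 2.1-fold lower number from compound 2 to compound 4 (0.32 log units; beyond the scatter), a first modest reading for that swap, though it rests on one pair of compounds only.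

As far as these compounds go, how the number would move with a longer chain or an amine in place of 4-methylbenzyl on the amide-type nitrogen stays open. The compounds shown also leave open whether the configuration at the two stereocentres would count for as much with phenyl on that nitrogen.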